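Urea series: amine chain variation, compound 2 to compound 4

This account rests on a few compounds, and the source may have more. Where it says the series, first, only, none or still open, it means among the compounds named here.

Measured compounds:
- compound 1 `CN(C)CCNc1nc(-c2ccc(NC(=O)Nc3ccc(Cl)cc3)cc2)nc2ccsc12`: 310 nM
- compound 2 `CN(C)CCNc1nc(-c2ccc(NC(=O)Nc3ccccc3Cl)cc2)nc2ccsc12`: 550 nM
- compound 3 `Cc1ccc(NC(=O)Nc2ccc(-c3nc(NCCN(C)C)c4sccc4n3)cc2)cc1`: 2180 nM

In a functional assay on MDA-MB-231 cells (Homo sapiens) for cytotoxicity, read by MTT assay, with a stated time of 72 h (a higher number here means a weaker inhibitor, a lower number a stronger inhibitor), compound 2 stands second highest of the three numbers. Its nearest neighbour is compound 1, the step of a 1.8-fold higher number from compound 1 to compound 2 (0.25 log units; within the scatter) lying within the scatter; its furthest is compound 3, the step of a 4.0-fold higher number from compound 2 to compound 3 (0.60 log units; beyond the scatter) lying beyond it. Compound 1 to compound 3 reads a 7.0-fold higher number from compound 1 to compound 3 (0.85 log units; beyond the scatter).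

Compound 4 `CCN(CC)CCCNc1nc(-c2ccc(NC(=O)Nc3ccccc3Cl)cc2)nc2ccsc12` keeps the urea aryl of compound 2 and changes only the amine side chain: (diethylamino)methyl in place of dimethylamino on a saturated chain carbon, two bonds along the chain from a nitrogen on an aromatic ring.

All three measured steps concern the urea aryl, none the amine chain, so none of them bears directly on this change. The measured set gives no steer on the chain in either direction. The working expectation is therefore that compound 4 stays close to compound 2 in this assay, with no step beyond the scatter, the estimated step being a 1.1-fold higher number from compound 2 to compound 4 (0.04 log units; within the scatter).

Among the measured compounds shown here, for compound 4 the estimate in this assay is 600 nM, with a range from 220 nM to 1700 nM, set wide since no measured step informs the chain change.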

Compound 4, half-maximal inhibitory concentration: 500 nM
For compound 4 the middle estimate is 1.2-fold (0.08 log units) above the measured one; measured number inside the range.
By their numbers in this assay, from the lowest: compounds 1, 4 and 2 (each within the scatter of the next); then compound 3.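

In this assay the only step shown that touches the amine chain, 3-(diethylamino)propyl in place of 2-(dimethylamino)ethyl on an unchanged urea aryl, reads a 1.1-fold lower number from compound 2 to compound 4 (0.04 log units; within the scatter) and so leaves compound 2 and compound 4 indistinguishable in this assay. Among the compounds shown here, this position therefore takes the larger group, with 6 heavy atoms where there were 3, without a step beyond the scatter, whereas the urea aryl has already given one in a 4.0-fold higher number from compound 2 to compound 3 (0.60 log units; beyond the scatter) and this is the first sign that the amine chain may be the more forgiving of the two sites. No data at hand offer a reason for this result.

On these data alone, the step alters chain length and the alkyl groups on the terminal amine together, so the share of each stays open, and 3-(dimethylamino)propyl or 2-(diethylamino)ethyl on the same urea would separate them. Also open, as far as these compounds go, are cyclic amines such as morpholine or piperidine at the chain end, a chain ending in a hydroxyl group, and whether the 3-(diethylamino)propyl chain behaves the same way with the 4-chlorophenyl urea of compound 1.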